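Small swaps, flat cytotoxicity: predicting compound 4

This account rests on a few compounds, and the source may have more. Where it says the series, first, only, none or still open, it means among the compounds named here.

Measured in an ADME assay on Huh7.5.1 cells (Homo sapiens) for cytotoxicity, read by ATP content, with a stated time of 48 h; on this read-out higher numbers stand for lower toxicity in this test and lower numbers for higher toxicity in this test:
compound 1 `Cc1oc(-c2c(C)c(C)c(C)c(C)c2C)nc1CN1CCC(C(=O)NCCCN2C[C@H](C)C[C@H](C)C2)CC1`: 8180 nM
compound 2 `Cc1oc(-c2c(Cl)cccc2Cl)nc1CN1CCC(C(=O)NCCCN2C[C@H](C)C[C@H](C)C2)CC1`: 13200 nM
compound 3 `CCc1ccccc1-c1nc(CN2CCC(C(=O)NCCCN3C[C@H](C)C[C@H](C)C3)CC2)c(C)o1`: 9320 nM

These three compounds share one core and differ only in the group on an aromatic carbon of its five-membered ring. Compound 3, at 9320 nM, cannot be separated from the other two, since its steps are a 1.1-fold higher number from compound 1 to compound 3 (0.06 log units; within the scatter) and a 1.4-fold lower number from compound 2 to compound 3 (0.15 log units; within the scatter). The remaining pair gives the same picture, with a 1.6-fold higher number from compound 1 to compound 2 (0.21 log units; within the scatter).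

The next compound, compound 4 `Cc1ccc(-c2nc(CN3CCC(C(=O)NCCCN4C[C@H](C)C[C@H](C)C4)CC3)c(C)o2)cc1C`, carries 3,4-dimethylphenyl in place of 2-ethylphenyl on an aromatic carbon. The two groups have the same atoms, joined differently.

All three measured steps bear on this change. Each replaces the same group, and none goes beyond the scatter in this assay. Within the data shown here, no measured compound carries 3,4-dimethylphenyl, so this reading is carried over from different groups and could fail. Even so, no step beyond the scatter is expected here. The estimated change is a 1.0-fold higher number from compound 3 to compound 4 (0.01 log units; within the scatter). For compound 4 the expected value is 9500 nM, with an estimated range from 5000 nM to 18000 nM.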

Compound 4, half-maximal cytotoxic concentration: 6910 nM
Beside the measured number, compound 4's estimate is 1.4-fold (0.14 log units) above it, within the range that was stated.
By their numbers in this assay, from the lowest: compounds 4, 1, 3 and 2 (each within the scatter of the next).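

Swapping 2-ethylphenyl for 3,4-dimethylphenyl keeps the same atoms but joins them differently, and in this assay this gives a 1.3-fold lower number from compound 3 to compound 4 (0.13 log units; within the scatter), so rearranging these carbons at this position produces no step that can be told apart from repeat-measurement noise. Compared with the other two groups, the new group gives a 1.9-fold lower number from compound 2 to compound 4 (0.28 log units; within the scatter) and a 1.2-fold lower number from compound 1 to compound 4 (0.07 log units; within the scatter); even the largest of these three steps stays within the scatter, so all four groups at this position leave the read-out flat. Nothing available here accounts for why these numbers lie so close together.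

On these data alone, all four groups are phenyl rings carrying only carbon or chlorine substituents, so it remains open whether an amine or a carboxylic acid on that ring would also leave this assay flat. The four compounds also share everything else in their structure, so they cannot show whether a change elsewhere on the shared core, such as a longer chain in place of the one leading from the amide, would shift the number beyond the scatter.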